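The source may hold more compounds than are shown below. What is called first, only, known or untested is meant among the compounds shown, and "the series" means these compounds.

Measured compounds in the series:
- compound 1, `COc1cc(C(F)(F)F)cc(SC)c1C(=O)NC1(c2cccc(F)c2)CCCN(C)C1`, 48 nM
- compound 2, `COc1cc(C(F)(F)F)cc(SC)c1C(=O)NC1(c2cccnc2)CCCN(C)C1`, 54 nM

Both numbers come from an assay on cells for inhibition of sodium- and chloride-dependent glycine transporter 1 (Homo sapiens); a higher number here means that more compound is needed for the effect, a lower number that less compound is needed. Compound 2 and compound 1 lie within the scatter of each other: the step of a 1.1-fold higher number from compound 1 to compound 2 (0.05 log units; within the scatter) changed nothing that the assay can resolve, so the two values give no order between them.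

Compound 3, `COc1cc(C(F)(F)F)cc(SC)c1C(=O)NC1(c2ccc(F)cn2)CCCN(C)C1`, has not been measured. It differs from compound 2 by 5-fluoropyridin-2-yl in place of pyridin-3-yl on a saturated ring carbon.

Within the data shown here, the only measured step that touches this position is the step from compound 1 to compound 2, and it was within the scatter. Among the measured compounds shown here, no measured pair covers the shift of the ring nitrogen or the added fluorine, so there is no basis for expecting a step beyond the scatter in this assay in either direction, while the unexplored change leaves room for a moderate move either way.

Compound 3 is therefore expected to give about 70 nM, with a plausible range from 25 nM to 200 nM, meaning an expected step of a 1.3-fold higher number from compound 2 to compound 3 (0.11 log units; within the scatter).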

Compound 3, half-maximal effective concentration: 180 nM
Estimate against measurement, compound 3: 2.6-fold (0.41 log units) below; the measured number falls inside the stated range.
By their numbers in this assay, from the lowest: compounds 1 and 2 (each within the scatter of the next); then compound 3.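

In this assay, the aromatic group on the saturated ring carbon proves not to be freely exchangeable: where the step between 3-fluorophenyl and pyridin-3-yl gave a 1.1-fold higher number from compound 1 to compound 2 (0.05 log units; within the scatter), 5-fluoropyridin-2-yl in place of pyridin-3-yl gives a 3.3-fold higher number from compound 2 to compound 3 (0.52 log units; beyond the scatter). Against the 3-fluorophenyl group, the same 5-fluoropyridin-2-yl group gives a 3.8-fold higher number from compound 1 to compound 3 (0.57 log units; beyond the scatter), so both steps to compound 3 run the same way and are of modest size, and the position responds to the identity of this ring even though the first exchange left no readable difference. Nothing available explains the loss, and the data cannot assign it to any feature of the entering group.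

The change from compound 2 to compound 3 alters the point of attachment on the pyridine and adds a fluorine in one step, so the share of each remains unresolved. Unsubstituted pyridin-2-yl and 5-fluoropyridin-3-yl would separate the two, and 5-chloropyridin-2-yl would show whether the fluorine itself can be exchanged at this position.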